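From fluoro to isopropyl on a shared core

The compounds below may be only part of what the source reports. "The series", "measured", "known", "first", "only" and "open" are said of these compounds alone.

Measured so far in a functional assay on MDA-MB-231 cells (Homo sapiens) for antiproliferative activity, with a stated time of 4 days (a lower number here means a stronger inhibitor, a higher number a weaker inhibitor), are these compounds
compound 1 `COc1ccc(-c2[nH]c3ccc(F)cc3c2C=O)cc1` gives 540 nM here
compound 2 `COc1ccc(-c2[nH]c3cc(Cl)ccc3c2C=O)cc1` gives 27 nM here
compound 3 `COc1ccc(-c2[nH]c3cc(Cl)c(C)cc3c2C=O)cc1` gives 26 nM here

Compound 1 carries the highest number of the three, and its gap to each of the other two lies beyond the scatter. The next compound to be measured is compound 4 `COc1ccc(-c2[nH]c3ccc(C(C)C)cc3c2C=O)cc1`, and its difference from compound 1 is isopropyl in place of fluoro on an aromatic carbon and amounts to isopropyl in place of fluoro on an aromatic carbon, meta to a fused ring and para to a fused ring.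

Within the data shown here, only one measured step bears on this change. It is methyl in place of hydrogen on an aromatic carbon, and it gives a 1.0-fold lower number from compound 2 to compound 3 (0.02 log units; within the scatter) in a pair that carries chloro. Among the measured compounds shown here, no measured compound carries isopropyl, and no measured step replaces fluoro, so the evidence is thin. With compound 3 at 26 nM showing that an added carbon group can leave the number unchanged, a moderate move toward a lower number is expected in this assay rather than a rise. The step expected is a 3.6-fold lower number from compound 1 to compound 4 (0.56 log units; beyond the scatter) and it remains uncertain. The expected value for compound 4 is 150 nM with 30 nM to 800 nM as its estimated range.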

Compound 4, half-maximal inhibitory concentration: 29 nM
Beside the measured number, compound 4's estimate is 5.2-fold (0.71 log units) above it; the measured number lies below the stated range.
By their numbers in this assay, from the lowest: compounds 3, 2 and 4 (each within the scatter of the next); then compound 1.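

In this assay, the place that is meta to a fused ring and para to a fused ring proves sensitive to the group it carries: isopropyl in place of fluoro gives a 19-fold lower number from compound 1 to compound 4 (1.27 log units; beyond the scatter), a large step. Among these compounds, the only earlier step between compounds differing in one place, a 1.0-fold lower number from compound 2 to compound 3 (0.02 log units; within the scatter), stayed within the scatter, so this is the first such step here to lie beyond it, and it comes with no change in rings, hydrogen-bond donors, hydrogen-bond acceptors or net charge, since neither fluoro nor isopropyl carries any of these. Among the compounds shown here, nothing available explains why this exchange moves the number so far.

With only fluoro and isopropyl shown at this place, the compounds leave open whether the lower number belongs to isopropyl in particular or would also appear with a methyl, a tert-butyl or a methoxy group. They also leave open how the number would respond to an amine or a carboxylic acid at the same carbon, and whether a longer chain there would hold it or lose it.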